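Swapping an aryl ether for a benzyl group

The source may hold more compounds than are shown below. What is called first, only, known or untested is meant among the compounds shown, and "the series" means these compounds.

Compound 3 `COc1ccc(Oc2ccc3c(NCCCNCc4cccc(OC)c4O)ccnc3c2)cc1` gives 14500 nM in a physicochemical assay for solubility, with a stated time of 18 h, at pH 7.4; a lower number here means a less soluble compound, a higher number a more soluble compound. Compound 1 `COc1ccc(Oc2ccc3c(NCCCNCc4cc(F)ccc4OC)ccnc3c2)cc1` gives 14500 nM in this assay and compound 2 `COc1cccc(CNCCCNc2ccnc3cc(Oc4ccc(Cl)cc4)ccc23)c1O` gives 14500 nM, so compound 3 stands level with both. The two measured steps, no change at the digits printed from compound 1 to compound 3 (within the scatter) and no change at the digits printed from compound 2 to compound 3 (within the scatter), each left the solubility within the scatter. Compound 4 `COc1cccc(CNCCCNc2ccnc3cc(Cc4ccccc4)ccc23)c1O` differs from compound 3 by benzyl in place of 4-methoxyphenoxy on an aromatic carbon. Neither measured step concerns this part of the shared core, so they bear only loosely on the case; they show that the changes made so far did not move the solubility. On that basis a small fall or no change beyond the scatter is expected, and the expected step is a 1.6-fold lower number from compound 3 to compound 4 (0.21 log units; within the scatter). Compound 4 is therefore estimated at 9000 nM, within a range of 3000 nM to 20000 nM.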

Compound 4, solubility: 4200 nM
Compound 4: middle estimate off by 2.1-fold (0.33 log units), on the high side; measured number inside the range.
By their numbers in this assay, from the lowest: compound 4; then compounds 1, 2 and 3 (each within the scatter of the next).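

Unlike the earlier steps, a change at this aromatic carbon of the shared core moves the number beyond the scatter in this assay: benzyl in place of 4-methoxyphenoxy gives (a 3.5-fold lower number from compound 3 to compound 4 (0.54 log units; beyond the scatter)), and benzyl in place of 4-chlorophenoxy gives (a 3.5-fold lower number from compound 2 to compound 4 (0.54 log units; beyond the scatter)). Both aryl ethers, whichever substituent they carry, stand apart from benzyl by the same step. Nothing available explains this difference. The compounds shown leave open whether a plain phenoxy, a phenyl or a morpholine at this position would sit with the aryl ethers or with benzyl.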